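Second trifluoromethyl group on the core of compound 3

A few compounds are considered here, and "the series" means these few. Any claim that something is new, unique, unknown or untested is made for them only; others in the source may bear on it.

Two pairs of compounds are compared here. Compound 1 `CC(O)(CSc1cccc(C(F)(F)F)c1)C(=O)Nc1ccc(S(F)(F)(F)(F)F)cc1` and compound 2 `CC(O)(CSc1cc(C(F)(F)F)cc(C(F)(F)F)c1)C(=O)Nc1ccc(S(F)(F)(F)(F)F)cc1` share one core, while compound 3 `CC(O)(COc1cccc(C(F)(F)F)c1)C(=O)Nc1ccc(S(F)(F)(F)(F)F)cc1` and compound 4 `CC(O)(COc1cc(C(F)(F)F)cc(C(F)(F)F)c1)C(=O)Nc1ccc(S(F)(F)(F)(F)F)cc1` share another; the difference between the two cores is not broken down here.

In a functional assay on VCaP cells (Homo sapiens) for antiproliferative activity, read by propidium iodide staining, with a stated time of 96 h (on this read-out lower numbers stand for stronger inhibition and higher numbers for weaker inhibition), compound 1 gives 18800 nM. Compound 2 gives 19400 nM in this assay. The change from compound 1 to compound 2 is trifluoromethyl in place of hydrogen on an aromatic carbon, and it made a 1.0-fold higher number from compound 1 to compound 2 (0.01 log units; within the scatter). Compound 3 gives 24700 nM in this assay; its value and those of compound 1 and compound 2 all lie within the usual scatter of one another, so no order among the three measured compounds can be claimed.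

Compound 4 carries the same change on the core of compound 3: trifluoromethyl in place of hydrogen on an aromatic carbon. The place description is the same word for word as in the first pair, so this is the same change, not merely the same kind.

On that basis the step from compound 3 to compound 4 is expected to be about a 1.0-fold higher number from compound 3 to compound 4 (0.01 log units; within the scatter), because the same change gave a 1.0-fold higher number from compound 1 to compound 2 (0.01 log units; within the scatter). Compound 4 is therefore estimated at 25000 nM in this assay. Given the scatter of such measurements, compound 4 is expected to fall between 12000 nM and 52000 nM. Among the measured compounds shown here, the expectation rests on a single prior instance of the change and on only three measured compounds.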

Compound 4, half-maximal inhibitory concentration: 2600 nM
Beside the measured number, compound 4's estimate is 9.6-fold (0.98 log units) above it; measured number outside the range, below it.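

In this assay, trifluoromethyl in place of hydrogen on an aromatic carbon gave a 9.5-fold lower number from compound 3 to compound 4 (0.98 log units; beyond the scatter), so the size of this step did not carry over from one core to the other: the same change on two cores in this assay, a 1.0-fold higher number (0.01 log units; within the scatter) from compound 1 to compound 2 and a 9.5-fold lower number (0.98 log units; beyond the scatter) from compound 3 to compound 4, 9.8-fold (0.99 log units) apart, beyond the scatter of two such steps.
The same change can therefore be silent on the core of compound 1 and still move the number beyond the scatter on the core of compound 3, and a step read on one of these cores is not a safe guide to the other in this series. This does not show which part of the difference between the two cores lies behind the gap, nor why the step differs, and with one pair per core it gives no general rule for other cores or for this change elsewhere on the ring.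

Still open, as far as these compounds go, is whether the step on the core of compound 3 belongs to trifluoromethyl itself, or whether a nitrile or a chlorine atom on the same aromatic carbon would give a step of similar size. Also open, from the compounds shown here alone, is which of the two outcomes a third core would follow, since two pairs cannot show which is the more usual one.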